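The compounds below may be only part of what the source reports. "The series", "measured", "known", "first", "only" and "open" are said of these compounds alone.

Measured so far:
- compound 1 `N#Cc1nc2c(-c3nc4ccccc4[nH]3)c(N)n(CCN3CCCC3)c2nc1C#N`: 6480 nM
- compound 2 `CCCCn1c(N)c(-c2nc3ccccc3[nH]2)c2nc(C#N)c(C#N)nc21`: > 50000 nM

Both values come from a functional assay on K562 cells (Homo sapiens) for antiproliferative activity, read by MTT assay, with a stated time of 48 h; on this read-out higher numbers stand for weaker inhibition and lower numbers for stronger inhibition. The value of compound 2, > 50000 nM, is a limit of this assay and not a number. That places compound 2 at the limit of > 50000 nM in this assay, at which 1 of the 2 values shown sits.

Compound 3 `N#Cc1nc2c(-c3nc4ccccc4[nH]3)c(N)n(CCCO)c2nc1C#N` differs from compound 2 in one place, hydroxy in place of methyl on a saturated chain carbon, three bonds along the chain from an aromatic nitrogen. Butyl thus becomes 3-hydroxypropyl.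

For the measured compounds named here, only one measured step bears on this, an at least 7.7-fold higher number from compound 1 to compound 2 (0.88 log units; beyond the scatter), which lies beyond the scatter. It shows that a change on this chain can shift the read-out, but it swaps a different group, ethyl in place of pyrrolidin-1-yl, so it is only a loose guide. A modest move towards lower numbers, meaning stronger inhibition, is expected, and compound 3 may well stay at the limit. The expected change is an at least 2.0-fold lower number from compound 2 to compound 3 (0.30 log units; that floor lies within the scatter). For compound 3 the estimated value is 25000 nM, with an expected range from 8000 nM to 50000 nM.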

Compound 3, half-maximal inhibitory concentration: > 50000 nM
Compound 3: only a limit was reported (the forecaster's own chance of this, stated with the estimate: 40%); at least 2.0-fold (0.30 log units) between middle value and limit.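

In this assay compound 3 gives > 50000 nM, which is a limit of the assay and not a number. Swapping the end of the chain from butyl to 3-hydroxypropyl gives no measurable gain here, as there is an at least 7.7-fold higher number from compound 1 to compound 3 (0.88 log units; beyond the scatter), so a chain ending in hydroxy falls short of the pyrrolidin-1-yl chain, just as butyl does. The step between the two limited compounds cannot be read, and the weak end of this small set is now more crowded: the limit of > 50000 nM in this assay, at which 2 of the 3 values shown sit.

Of the three compounds, only compound 1 gives a real number, but it cannot yet be said whether that depends on the pyrrolidin-1-yl ring itself or simply on having an amine at the end of the chain, which a dimethylamino or morpholin-4-yl group on the same chain could help to separate. As far as these compounds go, how far compound 2 and compound 3 lie beyond their limits also stays open, so any true difference between butyl and 3-hydroxypropyl remains hidden.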